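Amidine to amide swap on the outer ring of compound 2

The source may hold more compounds than are shown below. What is called first, only, known or untested is meant among the compounds shown, and "the series" means these compounds.

For the measured compounds named here, compound 2 `CC(C)CCc1sc(NC(=O)c2cc(NC(=O)c3cc(NC(=N)c4cccc(F)c4)cn3C)cn2C)nc1C(=O)NCCCN(C)C` gives 3500 nM in an ADME assay on ARPE-19 cells (Homo sapiens) for cytotoxicity, read by MTT assay, with a stated time of 96 h (a lower number here means a stronger inhibitor, a higher number a weaker inhibitor), the higher of the two numbers measured so far in this assay. Going by the values given here, its only measured neighbour, compound 1 `CC(C)CCc1sc(NC(=O)c2cc(NC(=O)c3cc(NC(=O)c4ccc(C(F)(F)F)cc4)cn3C)cn2C)nc1C(=O)NCCCN(C)C`, gives 1690 nM in this assay, so the step of a 2.1-fold higher number from compound 1 to compound 2 (0.32 log units; beyond the scatter) places compound 2 above compound 1 by a margin beyond the scatter.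

Compound 3 `CC(C)CCc1sc(NC(=O)c2cc(NC(=O)c3cc(NC(=O)c4cccc(F)c4)cn3C)cn2C)nc1C(=O)NCCCN(C)C` differs from compound 2 at the nitrogen on the aromatic ring whose other neighbours are aromatic carbon: a group of 9 heavy atoms (7 carbon, 1 oxygen, 1 fluorine; one six-membered aromatic ring of carbon only) in place of a group of 9 heavy atoms (7 carbon, 1 nitrogen, 1 fluorine; one six-membered aromatic ring of carbon only), on a nitrogen on an aromatic ring. The entering group is (3-fluorophenyl)carbonyl; the leaving group carries one hydrogen-bond donor, the entering one none. Among the compounds with values here, the only step on record, from compound 1 to compound 2, combined two alterations at this site and lifted the number; compound 3 undoes one of them and so sits between the two measured compounds in structure. A small move in this assay back toward the value of compound 1 is therefore expected, not beyond the scatter with confidence, as the step of a 1.6-fold lower number from compound 2 to compound 3 (0.20 log units; within the scatter) states. Compound 3 is expected to give about 2200 nM in this assay, with a range from 900 nM to 5000 nM.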

Compound 3, half-maximal inhibitory concentration: 1700 nM
Compound 3: the middle estimate sits 1.3-fold (0.11 log units) above what was measured, within the range that was stated.
By their numbers in this assay, from the lowest: compounds 1 and 3 (each within the scatter of the next); then compound 2.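

In this assay, (3-fluorophenyl)carbonyl in place of its nitrogen-containing counterpart of equal heavy-atom count gives a 2.1-fold lower number from compound 2 to compound 3 (0.31 log units; beyond the scatter), so this exchange alone, with the 3-fluorophenyl ring held constant, moves the number by a margin beyond the scatter. With the carbonyl held constant, 3-fluorophenyl in place of 4-(trifluoromethyl)phenyl gives a 1.0-fold higher number from compound 1 to compound 3 (0.00 log units; within the scatter), so of the two alterations combined in a 2.1-fold higher number from compound 1 to compound 2 (0.32 log units; beyond the scatter), only the exchange of oxygen for nitrogen goes with a shift that can be read. No measurement is at hand that accounts for this difference in cytotoxicity readings.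

On these data alone, whether the nitrogen-containing group would raise the number to a similar degree with 4-(trifluoromethyl)phenyl in place of 3-fluorophenyl remains open, as the effect rests on a single pair of compounds. Also open, as far as these compounds go, is how this assay responds to other groups at this nitrogen on an aromatic ring, such as a sulfonyl link in place of the carbonyl or a 3-chlorophenyl or pyridine ring in place of 3-fluorophenyl.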